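This account rests on a few compounds, and the source may have more. Where it says the series, first, only, none or still open, it means among the compounds named here.

Compound 1 `O=S(=O)(Nc1ccc(-c2nc3ccccc3o2)cc1)c1ccccc1Cl` is one of two compounds already measured. In an ADME assay on HEK293 cells (Homo sapiens) for cytotoxicity, read by resazurin assay, with a stated time of 48 h (on this read-out higher numbers stand for lower toxicity in this test and lower numbers for higher toxicity in this test), compound 1 gives only a limit, > 100000 nM, and not a number. Compound 2 `O=S(=O)(Nc1ccc2oc(-c3ccccc3)nc2c1)c1ccccc1Cl` gives in this assay a value of 73000 nM. Compound 3 `O=S(=O)(Nc1ccc(-c2nc3ccccc3o2)cc1)c1ccc(Cl)cc1` has the same atoms as compound 1 but carries 4-chlorophenyl in place of 2-chlorophenyl on a sulfonyl sulfur. Going by the values given here, no measured pair changes a group in this way, and compound 1 sits at the limit of > 100000 nM in this assay, at which 1 of the 2 values shown sits, so the step of a number no higher from compound 1 to compound 3 (the limit leaves the size open) is expected to be none beyond the scatter. Compound 3 is therefore estimated at 100000 nM, with a range from 50000 nM to 200000 nM, and most likely reported again only as a limit.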

Compound 3, half-maximal cytotoxic concentration: > 100000 nM
Compound 3 was reported as a limit; the forecaster's own chance of this, stated with the estimate: 65%; the middle value lies on the limit itself.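

Going by these compounds alone, compound 1 and compound 3 both stand only as limits in this assay, so no step between them can be read. The compounds shown leave open whether 4-chlorophenyl in place of 2-chlorophenyl on a sulfonyl sulfur changes the read-out at all.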